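This account rests on a few compounds, and the source may have more. Where it says the series, first, only, none or still open, it means among the compounds named here.

Three compounds of this series carry numbers from a functional assay on Mahlavu cells (Homo sapiens) for inhibition, read by sulforhodamine B assay, with a stated time of 72 h; on this read-out higher numbers stand for weaker inhibition and lower numbers for stronger inhibition. Compound 1, `Cc1ccc(C2=Nn3c(nnc3C(C)c3ccc(CC(C)C)cc3)SC2)cc1`, gives 8500 nM. Compound 2, `CC(C)Cc1ccc(C(C)c2n[nH]c(=S)n2N)cc1`, gives 16200 nM. Compound 3, `CC(c1ccc(-c2ccccc2)c(F)c1)c1nnc2n1N=C(c1ccc(Cl)cc1)CS2`, gives 6100 nM. Compound 3 holds the lowest of the three numbers; the gap to compound 1 falls within the scatter, so no order between compound 3 and compound 1 can be read from these two values, while the gap to compound 2 lies beyond the scatter. Among the measured compounds shown here, no two of the measured compounds differ in a single place, so there is no measured step in this assay to lean on.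

Compound 4, `CC(c1ccc(-c2ccccc2)c(F)c1)c1nnc2n1N=C(c1ccc(F)cc1)CS2`, has not yet been measured in this assay. It differs from compound 3 in one place: fluoro in place of chloro on an aromatic carbon. For the measured compounds named here, nothing among the measured compounds shows what this swap does in this assay, so the expectation rests on the change alone. The expected step is a 1.2-fold higher number from compound 3 to compound 4 (0.09 log units; within the scatter), small, within the scatter, with no direction that can be defended from the numbers at hand. Compound 4 is thus expected to give about 7500 nM in this assay, with a range from 3500 nM to 16000 nM.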

Compound 4, half-maximal inhibitory concentration: 7400 nM
Estimate against measurement, compound 4: 1.0-fold (0.01 log units) above; the measured number falls inside the stated range.
By their numbers in this assay, from the lowest: compounds 3, 4, 1 and 2 (each within the scatter of the next, the first and the last beyond it).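

Among the compounds shown here, this is the first single-place step: in this assay, the change from 4-chlorophenyl to 4-fluorophenyl gives a 1.2-fold higher number from compound 3 to compound 4 (0.08 log units; within the scatter), so no order can be set between chloro and fluoro at this position, on an aromatic carbon para to a large group. The earlier compounds shown here, none of them a single-place neighbour of another, could not show how any one group bears on the number; this pair shows that, for these two halogens at this position, the exchange does not move the number beyond the scatter. No measurement on either group bears on this result, so the data give no account of why the pair reads as it does.

As far as these compounds go, what an amine, a carboxylic acid or a longer chain at this same position would do to the number stays open, so it remains unknown whether the position responds to a group of a different kind. Also open, from the compounds shown here alone, is whether the exchange of chloro for fluoro would read the same with a different group elsewhere on the shared core.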